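A Second Trifluoromethyl Group on Compound 2

A few compounds are considered here, and "the series" means these few. Any claim that something is new, unique, unknown or untested is made for them only; others in the source may bear on it.

Compound 2 `COc1cc(Cl)cc(-c2nn(-c3cccc(NC(=O)c4cccc(C(F)(F)F)c4)c3)cc2-c2ccncc2)c1` gives 64.2% in a functional assay on SF-539 cells (Homo sapiens) for inhibition, read by sulforhodamine B assay, with a stated time of 48 h, tested at 10 uM (on this read-out higher numbers stand for a weaker effect at the one concentration tested and lower numbers for a stronger effect), the highest of the two numbers measured. Going by the values given here, its only neighbour, compound 1 `COc1cc(Cl)cc(-c2nn(-c3cccc(NC(=O)Nc4cccc(C(F)(F)F)c4)c3)cc2-c2ccncc2)c1`, gives 17%, and the step of a number 47.2 percentage points higher from compound 1 to compound 2 (beyond the scatter) concerns the group on the carbonyl carbon, not the aromatic ring. Compound 3 `COc1cc(Cl)cc(-c2nn(-c3cccc(NC(=O)c4cc(C(F)(F)F)cc(C(F)(F)F)c4)c3)cc2-c2ccncc2)c1` differs from compound 2 by trifluoromethyl in place of hydrogen on an aromatic carbon. Among the compounds with values here, no measured step bears on this change, so nothing in the data points to a shift beyond the scatter in this assay in either direction. Compound 3 is therefore expected to give about 60%, between 35% and 85%, a step of a number 4.2 percentage points lower from compound 2 to compound 3 (within the scatter).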

Compound 3, a percentage reported as activity, at one concentration (the size of the read-out at that concentration, not a potency): 80%
Compound 3: middle estimate off by 20 percentage points, on the low side; the measured number falls inside the stated range.
By their numbers in this assay, from the lowest: compound 1; then compound 2; then compound 3.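

Going by these compounds alone, the ring carrying the trifluoromethyl group had not been varied in the earlier compounds, whose only step lay at the group on the carbonyl carbon. In this assay, the second trifluoromethyl group, meta to a large group and meta to a trifluoromethyl group, gives a number 15.8 percentage points higher from compound 2 to compound 3 (beyond the scatter), so this position also affects the read-out, and the added group weakens the effect at the one concentration tested. Nothing available explains this shift. The compounds shown leave open whether a smaller fluorine atom, a methoxy group or an amine at this position would weaken the effect likewise. They also leave open whether a second trifluoromethyl group would do the same on the urea of compound 1.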